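A few compounds are considered here, and "the series" means these few. Any claim that something is new, unique, unknown or untested is made for them only; others in the source may bear on it.

In a functional assay on HUVEC cells (Homo sapiens) for antiproliferative activity, read by MTT assay, with a stated time of 24 h (on this read-out higher numbers stand for weaker inhibition and lower numbers for stronger inhibition), compound 1 `COc1cccc(C(=O)Oc2ccc3c(=O)c(-c4cc(OC)c(OC)cc4OC)coc3c2)c1` gives > 10000 nM, which is a limit of the assay and not a number. Compound 2 `COc1cc(OC)c(-c2coc3cc(OCc4ccc(Br)cc4)ccc3c2=O)cc1OC` gives > 10000 nM, which is also a limit. Among the measured compounds shown here, neither compound has a number of its own, and the series so far rests on (the limit of > 10000 nM in this assay, at which 2 of the 2 values shown sit). For the measured compounds named here, the only measured step is a step that the two limits leave unreadable from compound 1 to compound 2, so it offers no size to carry forward.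

Compound 3 `COc1cc(OC)c(-c2coc3cc(OCc4ccc(Cl)cc4)ccc3c2=O)cc1OC` follows from compound 2 by chloro in place of bromo on an aromatic carbon, para to a large group. Going by the values given here, no measured step covers this exchange. With compound 2 at > 10000 nM, no step beyond the scatter is expected in this assay, and no direction can be assigned. The expected step is a step that the limit leaves unreadable from compound 2 to compound 3. For compound 3 the estimated value is 15000 nM, with an expected range from 7000 nM to 40000 nM.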

Compound 3, half-maximal inhibitory concentration: 4400 nM
Beside the measured number, compound 3's estimate is 3.4-fold (0.53 log units) above it; the measured number lies below the stated range.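

In this assay, chloro in place of bromo on the aromatic carbon, para to a large group, gives an at least 2.2-fold lower number from compound 2 to compound 3 (0.35 log units; beyond the scatter), so this carbon responds to a change of one heavy atom. On the oxygen on the aromatic ring, 4-chlorobenzyl in place of (3-methoxyphenyl)carbonyl gives an at least 2.2-fold lower number from compound 1 to compound 3 (0.35 log units; beyond the scatter), a readable step at a place where 4-bromobenzyl left none. Among the compounds shown here, compound 3 is the only compound with a number of its own, and the other two remain limits: the limit of > 10000 nM in this assay, at which 2 of the 3 values shown sit.

As far as these compounds go, the full size of both steps stays open, as each is bounded from one side only. Also open, from the compounds shown here alone, is how fluoro, methoxy or an amine on the same carbon, or an unsubstituted benzyl on the oxygen, would read against compound 3.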